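The source may hold more compounds than are shown below. What is called first, only, known or untested is meant among the compounds shown, and "the series" means these compounds.

The measured compounds are compound 1 `CC(C(=O)NCc1ccc(C(F)(F)F)nc1-c1ccc(F)c(Cl)c1)c1ccc(NS(C)(=O)=O)c(F)c1`, which in an assay on CHO cells for antagonist activity at transient receptor potential cation channel subfamily V member 1 (Homo sapiens), read by FLIPR (a higher number here means a weaker inhibitor, a lower number a stronger inhibitor), gives 0.2 nM, and compound 2 `CC(C(=O)NCc1ccc(C(F)(F)F)nc1-c1ccco1)c1ccc(NS(C)(=O)=O)c(F)c1`, which in this assay gives 5.8 nM.

Compound 1 holds the lowest of the two numbers; its nearest neighbour is compound 2, separated by the step of a 29-fold higher number from compound 1 to compound 2 (1.46 log units; beyond the scatter). Compound 3 `Cc1ccc(CCc2nc(C(F)(F)F)ccc2CNC(=O)C(C)c2ccc(NS(C)(=O)=O)c(F)c2)cc1` has not yet been measured in this assay. It differs from compound 1 in one place: 2-(4-methylphenyl)ethyl in place of 3-chloro-4-fluorophenyl on an aromatic carbon. For the measured compounds named here, the only measured step that bears on this position is the one from compound 1 to compound 2, which was large and ran toward weaker inhibition when the 3-chloro-4-fluorophenyl was exchanged. Going by the values given here, no measured step shows a 2-(4-methylphenyl)ethyl group at this place, so compound 3 is judged by analogy only. Compound 3 is expected to give a higher number than compound 1, a step of about a 25-fold higher number from compound 1 to compound 3 (1.40 log units; beyond the scatter), because a 29-fold higher number from compound 1 to compound 2 (1.46 log units; beyond the scatter) was large. The estimate for compound 3 in this assay is 5 nM, with a range from 1 nM to 30 nM.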

Compound 3, inhibition constant: 0.6 nM
Compound 3: the middle estimate sits 8.3-fold (0.92 log units) above what was measured; measured number below the stated range.
By their numbers in this assay, from the lowest: compound 1; then compound 3; then compound 2.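

In this assay, the place next to the ring nitrogen accepts 2-(4-methylphenyl)ethyl in exchange for 3-chloro-4-fluorophenyl with only a modest change (a 3.0-fold higher number from compound 1 to compound 3 (0.48 log units; beyond the scatter)), so the large step seen with furan-2-yl does not hold for every replacement of that group. The same group also compares well with furan-2-yl (a 9.7-fold lower number from compound 2 to compound 3 (0.99 log units; beyond the scatter)), and among these three compounds both groups with a six-membered aromatic ring of carbon only give lower numbers than furan-2-yl. Nothing available gives a reason for either step.

The compounds shown do not separate the effect of the ethyl chain from that of the ring substituents, since the two change together in compound 3. From the compounds shown here alone, it also stays open whether a longer chain, an amine or a simple unsubstituted phenyl at this place would keep the number as low.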